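Chlorophenyl urea series: a change of substituent position

A few compounds are considered here, and "the series" means these few. Any claim that something is new, unique, unknown or untested is made for them only; others in the source may bear on it.

Of the compounds shown here, three have been measured in a functional assay on B16-F10 cells (Mus musculus) for inhibition, read by MTT assay, with a stated time of 72 h; on this read-out higher numbers stand for weaker inhibition and lower numbers for stronger inhibition. Compound 1 `CC1(C)CC(NC(=O)Nc2ccc(Cl)cc2)c2cc(Br)ccc2O1` gives 9000 nM, the highest of the three numbers, though its gaps to the other two lie within the scatter. Compound 2 `CC1(C)CC(NC(=S)Nc2cccc(Cl)c2)c2cc(Br)ccc2O1` gives 7000 nM, and compound 3 `CC1(C)CC(NC(=S)Nc2cccc(C#N)c2)c2cc(Cl)ccc2O1` gives 6000 nM. For the measured compounds named here, no pair of measured compounds differs in a single place, so no isolated step is available. Compound 4 `CC1(C)CC(NC(=O)Nc2ccccc2Cl)c2cc(Br)ccc2O1` has not yet been measured; it differs from compound 1 by 2-chlorophenyl in place of 4-chlorophenyl on an amide-type nitrogen. Going by the values given here, with no comparable step among the measured compounds, the expected change is none beyond the scatter, in either direction. For compound 4 the expected value in this assay is 9000 nM, in a range of 4000 nM to 20000 nM. The step this estimate implies, no change at the digits printed from compound 1 to compound 4 (within the scatter), is expected to stay within the scatter.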

Compound 4, half-maximal inhibitory concentration: 22000 nM
Compound 4: the middle estimate sits 2.4-fold (0.39 log units) below what was measured; measured number above the stated range.
By their numbers in this assay, from the lowest: compounds 3, 2 and 1 (each within the scatter of the next); then compound 4.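

With the same atoms joined differently, 2-chlorophenyl in place of 4-chlorophenyl on the amide-type nitrogen gives a 2.4-fold higher number from compound 1 to compound 4 (0.39 log units; beyond the scatter) in this assay and so weaker inhibition. For the compounds shown here, this is the first single-place step and it lies beyond the scatter, so the location of the chlorine on this phenyl ring matters here. No measured evidence bears on the cause of this step.
Open, going by these compounds, is whether the same exchange reads alike with the thiocarbonyl of compound 2 in place of the carbonyl. Also open, on these data alone, is how a methoxy group or a carboxylic acid would read in place of the chlorine.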